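A few compounds are considered here, and "the series" means these few. Any claim that something is new, unique, unknown or untested is made for them only; others in the source may bear on it.

Going by the values given here, compound 1 `O=C1C(=O)N(CCCCn2cc(COc3cc(=O)oc4ccccc34)nn2)c2ccc([N+](=O)[O-])cc21` stands at the top of the two numbers so far in a functional assay on THP-1 cells (Homo sapiens) for inhibition, read by sulforhodamine B assay, with a stated time of 48 h, tested at 50 uM; a higher number here means more inhibition of growth at the concentration tested, a lower number less inhibition of growth: compound 1 gives 55%, while compound 2 `O=C1C(=O)N(CCCCCn2cc(COc3cc(=O)oc4ccccc34)nn2)c2ccc(I)cc21` gives 45%, a gap that lies within the usual scatter, so the two cannot be told apart. Compound 3 `O=C1C(=O)N(CCCCn2cc(COc3cc(=O)oc4ccccc34)nn2)c2ccccc21` has not yet been measured; it differs from compound 1 in one place: hydrogen in place of nitro on an aromatic carbon. Among the compounds with values here, no measured pair shows what this change does, so the step is expected to be modest, a number 10 percentage points lower from compound 1 to compound 3 (within the scatter) in this assay, a slight fall that may not exceed the scatter. Compound 3 is therefore estimated at 45%, with a likely range from 25% to 65%.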

Compound 3, percent growth inhibition at one concentration: 85%
Compound 3: middle estimate off by 40 percentage points, on the low side, outside the stated range (above it).
By their numbers in this assay, from the lowest: compounds 2 and 1 (each within the scatter of the next); then compound 3.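

Going by these compounds alone, replacing nitro with hydrogen on this aromatic carbon is the first change that can be read on its own: in this assay it gives a number 30 percentage points higher from compound 1 to compound 3 (beyond the scatter). This position therefore matters for growth inhibition, and here the unsubstituted carbon outperforms the nitro-bearing one. The data offer no explanation for this rise.

From the compounds shown here alone, whether an amine, a methoxy group or a fluorine at this position would match hydrogen remains open. So does the effect of a longer chain in compound 3, since compound 2 differs from it in more than one place.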